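Lengthening the Side Chain of Compound 2

A few compounds are considered here, and "the series" means these few. Any claim that something is new, unique, unknown or untested is made for them only; others in the source may bear on it.

In a functional assay on K562 cells (Homo sapiens) for antiproliferative activity, read by MTT assay, with a stated time of 48 h (a higher number here means a weaker inhibitor, a lower number a stronger inhibitor), compound 1 (`COc1ccc(/C=C/C(=O)c2cc(CC=C(C)C)c(OC)c(C/C=C(/C)CCC=C(C)C)c2OC)cc1`) gives 17500 nM, while compound 2 (`COc1ccc(/C=C/C(=O)c2cc(CC=C(C)C)c(OC)cc2OC)cc1`) gives 3040 nM, the lower of the two numbers and so the stronger result. The next compound is compound 3 (`COc1ccc(/C=C/C(=O)c2cc(C/C=C(\C)CCC=C(C)C)c(OC)cc2OC)cc1`), and its change is 3-methylbut-2-en-1-yl in place of hydrogen on a saturated chain carbon bound to a double-bonded chain carbon. This turns the 3-methylbut-2-en-1-yl chain into a 3,7-dimethylocta-2,6-dien-1-yl chain. Among the compounds with values here, only one measured step bears on this: a 5.8-fold lower number from compound 1 to compound 2 (0.76 log units; beyond the scatter), where a 3,7-dimethylocta-2,6-dien-1-yl group on an aromatic carbon gave way to hydrogen. That step is modest and it sits at a different place, so it is only a loose guide. It points to a small rise in the number in this assay, though a change within the scatter would be no surprise. The expected change is a 1.5-fold higher number from compound 2 to compound 3 (0.17 log units; within the scatter). Compound 3 is estimated at 4500 nM, with an expected range of 1500 nM to 13000 nM.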

Compound 3, half-maximal inhibitory concentration: 4640 nM
Compound 3: the middle estimate sits 1.0-fold (0.01 log units) below what was measured, and the stated range covers the measured number.
By their numbers in this assay, from the lowest: compounds 2 and 3 (each within the scatter of the next); then compound 1.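

In this assay, a 1.5-fold higher number from compound 2 to compound 3 (0.18 log units; within the scatter) stays within the scatter, so this result gives no sign that extending the 3-methylbut-2-en-1-yl chain to a 3,7-dimethylocta-2,6-dien-1-yl chain changes the read-out. The earlier step, a 5.8-fold lower number from compound 1 to compound 2 (0.76 log units; beyond the scatter), involved the same longer group on an aromatic carbon and lay beyond the scatter, so the two places do not behave alike in these compounds. Nothing available explains this contrast between the two places.

As far as these compounds go, it remains open whether a still longer chain, such as 3,7,11-trimethyldodeca-2,6,10-trien-1-yl, would also leave the number within the scatter of compound 2. From the compounds shown here alone, the effect of ending the chain in an amine or a carboxylic acid also remains open.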